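Swapping the thioester of compound 3 for a sec-butyl ester

The source may hold more compounds than are shown below. What is called first, only, known or untested is meant among the compounds shown, and "the series" means these compounds.

Measured so far:
- compound 1, `CCNC(=O)C1=C(C)NC(=O)NC1c1ccsc1`: 1%
- compound 2, `CCN(CC)C(=O)C1=C(C)NC(=O)NC1c1ccsc1`: 35%
- compound 3, `CCSC(=O)C1=C(C)NC(=O)NC1c1ccsc1`: 2%

All three compounds share one core and differ only in the group attached to the carbonyl carbon. In an assay on membranes from HeLa cells for displacement of a labelled ligand from adenosine receptor A3 (Homo sapiens), read by scintillation counting, with a stated time of 180 min, tested at 1 uM (on this read-out higher numbers stand for more inhibition at the one concentration tested (going by the name of the read-out) and lower numbers for less inhibition), compound 3 gives 2%, second highest of the three numbers; its nearest neighbour is compound 1, with a number 1 percentage points higher from compound 1 to compound 3 (within the scatter), and its furthest is compound 2, with a number 33 percentage points lower from compound 2 to compound 3 (beyond the scatter).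

Compound 4, `CCC(C)OC(=O)C1=C(C)NC(=O)NC1c1ccsc1`, is not yet measured. It differs from compound 3 in one place: sec-butoxy in place of ethylsulfanyl on a carbonyl carbon.

No measured step exchanges a sulfur-linked group for an oxygen-linked one, so the expectation rests on what the carbonyl position has shown. Replacing ethylamino with ethylsulfanyl gave a number 1 percentage points higher from compound 1 to compound 3 (within the scatter), while the single large move came from the diethylamino group, a number 34 percentage points higher from compound 1 to compound 2 (beyond the scatter). A sec-butoxy group is neither, so only a small step is expected, a number 6 percentage points higher from compound 3 to compound 4 (within the scatter), staying within the scatter or slightly above it. Compound 4 is therefore estimated at 8%, with a range from -5% to 30%.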

Compound 4, a percentage reported as inhibition, at one concentration (the size of the read-out at that concentration, not a potency): 7%
Compound 4: middle estimate off by 1 percentage points, on the high side, and the stated range covers the measured number.
By their numbers in this assay, from the lowest: compounds 1, 3 and 4 (each within the scatter of the next); then compound 2.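

In this assay, the sec-butoxy group of compound 4 brings an oxygen-linked group to the carbonyl carbon, and it cannot be told apart from the ethylsulfanyl group (a number 5 percentage points higher from compound 3 to compound 4 (within the scatter)) or the ethylamino group (a number 6 percentage points higher from compound 1 to compound 4 (within the scatter)). The diethylamino group stays clearly separate from sec-butoxy (a number 28 percentage points lower from compound 2 to compound 4 (beyond the scatter)), so compound 2 alone stands apart among these four compounds, and the 5 heavy atoms of sec-butoxy against the 3 of ethylsulfanyl bring no change beyond the scatter. Nothing available explains what sets diethylamino apart from the other groups.

An ethoxy group would show how oxygen compares with sulfur when the ethyl chain stays the same, since this step changes both. A dimethylamino group would show whether other amides with two groups on nitrogen behave like compound 2.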